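The source may hold more compounds than are shown below. What is called first, only, known or untested is meant among the compounds shown, and "the series" means these compounds.

In a functional assay on CCRF-CEM cells (Homo sapiens) (a higher number here means that more compound is tolerated, a lower number that less compound is tolerated), the measured compounds are: compound 1 `CCNC(=O)NC1=CS(=O)(=O)O[C@@]12[C@@H](CO[Si](C)(C)C(C)(C)C)O[C@@H](n1cc(C)c(=O)n(C)c1=O)[C@@H]2O[Si](C)(C)C(C)(C)C` at 4260 nM; compound 2 `Cc1cn([C@@H]2O[C@H](CO[Si](C)(C)C(C)(C)C)[C@@]3(OS(=O)(=O)C=C3NCCC(=O)O)[C@H]2O[Si](C)(C)C(C)(C)C)c(=O)n(C)c1=O` at 19400 nM; compound 3 `COC(=O)CNC1=CS(=O)(=O)O[C@@]12[C@@H](CO[Si](C)(C)C(C)(C)C)O[C@@H](n1cc(C)c(=O)n(C)c1=O)[C@@H]2O[Si](C)(C)C(C)(C)C` at 96000 nM.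

Compound 3 gives the highest of the three numbers, standing a 4.9-fold higher number from compound 2 to compound 3 (0.69 log units; beyond the scatter) and a 23-fold higher number from compound 1 to compound 3 (1.35 log units; beyond the scatter). Compound 4 `CC(=O)NC1=CS(=O)(=O)O[C@@]12[C@@H](CO[Si](C)(C)C(C)(C)C)O[C@@H](n1cc(C)c(=O)n(C)c1=O)[C@@H]2O[Si](C)(C)C(C)(C)C` has not been measured; it differs from compound 3 thus: acetyl in place of (methoxycarbonyl)methyl on an amine nitrogen. Acetyl, like the ethylcarbamoyl of compound 1, joins the amine nitrogen through a carbonyl, so the step from compound 1 to compound 3 bears most, and the step from compound 2 to compound 3 points the same way. Both ran upward toward compound 3 and both lay beyond the scatter, so a downward step, probably a large one, is expected for compound 4. Compound 4 is therefore estimated at 8000 nM, within 2000 nM to 40000 nM, which would mean a 12-fold lower number from compound 3 to compound 4 (1.08 log units; beyond the scatter).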

Compound 4, half-maximal cytotoxic concentration: 25700 nM
Compound 4: middle estimate off by 3.2-fold (0.51 log units), on the low side; the range from low to high includes it.
By their numbers in this assay, from the lowest: compound 1; then compounds 2 and 4 (each within the scatter of the next); then compound 3.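

In this assay acetyl on the amine nitrogen gives a lower number than (methoxycarbonyl)methyl (a 3.7-fold lower number from compound 3 to compound 4 (0.57 log units; beyond the scatter)) but a higher one than ethylcarbamoyl (a 6.0-fold higher number from compound 1 to compound 4 (0.78 log units; beyond the scatter)). Both acetyl and ethylcarbamoyl join this nitrogen through a carbonyl, yet the step between them lies beyond the scatter, so a carbonyl link alone does not fix the number. Acetyl and 2-carboxyethyl cannot be told apart here (a 1.3-fold higher number from compound 2 to compound 4 (0.12 log units; within the scatter)).

Open, as far as these compounds go, is how a plain amine or a longer acyl chain on this nitrogen would compare. No measurement at hand accounts for these steps.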